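Trimming the piperidine to a dimethylamino group

A few compounds are considered here, and "the series" means these few. Any claim that something is new, unique, unknown or untested is made for them only; others in the source may bear on it.

Compound 2 `CC1(N)CCN(c2ncnc3[nH]cc(-c4cccc(Cl)c4)c23)CC1` gives 278 nM in an assay for inhibition of serine/threonine-protein kinase 3 (Homo sapiens), read by luminescence and ADP-Glo, in the presence of a further agent that is not named here (a lower number here means a stronger inhibitor, a higher number a weaker inhibitor), the lower of the two numbers shown. Compound 1 `CNC1CCN(c2ncnc3[nH]cc(-c4cccc(Cl)c4)c23)CC1` gives 293 nM, and the step of a 1.1-fold lower number from compound 1 to compound 2 (0.02 log units; within the scatter) stays within the scatter. Compound 3 `CN(C)c1ncnc2[nH]cc(-c3cccc(Cl)c3)c12` differs from compound 2 by dimethylamino in place of 4-amino-4-methylpiperidin-1-yl on an aromatic carbon. No measured step removes the six-membered ring, so the single step shown does not bear directly on this change. Compound 3 is expected to give a higher number, an estimated step of a 5.4-fold higher number from compound 2 to compound 3 (0.73 log units; beyond the scatter). Compound 3 is therefore estimated at 1500 nM, within a range from 400 nM to 6000 nM.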

Compound 3, half-maximal inhibitory concentration: 349 nM
Compound 3: the middle estimate sits 4.3-fold (0.63 log units) above what was measured; measured number below the stated range.
By their numbers in this assay, from the lowest: compounds 2, 1 and 3 (each within the scatter of the next).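

In this assay, this aromatic carbon accepts a much smaller group than either piperidine: dimethylamino, with no ring and no hydrogen-bond donor, gives a 1.3-fold higher number from compound 2 to compound 3 (0.10 log units; within the scatter) and a 1.2-fold higher number from compound 1 to compound 3 (0.08 log units; within the scatter). Across these compounds, then, neither the six-membered ring nor its amine separates the numbers. No measurement given here explains this.

From the compounds shown here alone, it remains open whether a group without nitrogen at this carbon, such as methyl, methoxy or a carboxylic acid, would stay in the same range. A longer chain ending in an amine is equally untested by the compounds shown.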